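One Methoxy Less on the Amine Aryl

A few compounds are considered here, and "the series" means these few. Any claim that something is new, unique, unknown or untested is made for them only; others in the source may bear on it.

Among the compounds with values here, compound 3 `COc1ccc(Nc2cccc3c(C)c(C)sc23)cc1OC` stands highest of the three numbers measured so far. In a functional assay for inhibition, with a stated time of 2 h, tested at 0.250 g/L (on this read-out lower numbers stand for less inhibition and higher numbers for more inhibition at the one concentration tested (going by the name of the read-out)), compound 3 gives 100%. Its nearest neighbour is compound 2 `Cc1sc2c(Nc3cccnc3)cccc2c1C`, which in this assay gives 86.2%, a gap beyond the scatter. Furthest is compound 1 `Cc1sc2c(Nc3ccc(C#N)cc3)cccc2c1C`, which in this assay gives 79.6%, also beyond the scatter. Compound 4 `COc1ccc(Nc2cccc3c(C)c(C)sc23)cc1` has not been measured. It differs from compound 3 in one place: hydrogen in place of methoxy on an aromatic carbon. A methoxy group leaves and a hydrogen atom enters on an aromatic carbon of the six-membered aromatic ring of carbon only. Within the data shown here, no step between two measured compounds that differ in one place is available, so the size of this change cannot be read from a precedent. Since compound 1 reaches only 79.6% and compound 2 only 86.2% in this assay, both below compound 3, a loss of inhibition seems more likely than a gain. The expected step in this assay, a number 10 percentage points lower from compound 3 to compound 4 (within the scatter), is a loss of modest size that may still fall within the scatter. Compound 4 is therefore estimated at 90%, within a range from 75% to 100%.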

Compound 4, a percentage reported as inhibition, at one concentration (the size of the read-out at that concentration, not a potency): 100%
Compound 4: the middle estimate sits 10 percentage points below what was measured, and the stated range covers the measured number.
By their numbers in this assay, from the lowest: compounds 1 and 2 (each within the scatter of the next); then compounds 3 and 4 (each within the scatter of the next).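

In this assay, taking one methoxy group off the six-membered aromatic ring of carbon only gives no change at the digits printed from compound 3 to compound 4 (within the scatter), so at the one concentration tested this position accepts hydrogen as well as methoxy. Methoxy in place of cyano on an aromatic carbon gives a number 20.4 percentage points higher from compound 1 to compound 4 (beyond the scatter), which shows that the read-out does respond to a single change on this ring, though only to this one of the two changes so far. No measurement offered here accounts for either result.

The compounds shown leave open what happens when the methoxy group that remains on compound 4 gives way to hydrogen, an amine or a carboxylic acid. Since this read-out is not a potency, they also leave open whether compound 3 and compound 4 would still match at lower concentrations.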